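Chloro on the fused ring of the weakest analogue

This account rests on a few compounds, and the source may have more. Where it says the series, first, only, none or still open, it means among the compounds named here.

Three compounds share one core and differ only in one group on a pendant aromatic ring. Compound 1 `COc1ccc(C2CC(c3ccccc3)=NN2C2=NC(=O)/C(=C3\C(=O)Nc4ccccc43)S2)cc1` carries a methoxy there; compound 2 `O=C1N=C(N2N=C(c3ccccc3)CC2c2ccc(Cl)cc2)S/C1=C1/C(=O)Nc2ccccc21` a chloro; compound 3 `CN(C)c1ccc(C2CC(c3ccccc3)=NN2C2=NC(=O)/C(=C3\C(=O)Nc4ccccc43)S2)cc1` a dimethylamino. In a functional assay on cells (Cancer cell lines, Homo sapiens) for cytotoxicity, read by sulforhodamine B assay, with a stated time of 48 h (a higher number here means a weaker inhibitor of growth, a lower number a stronger inhibitor of growth), compound 1 gives 4390 nM, compound 2 gives 390 nM, and compound 3 gives 35300 nM, the highest of the three numbers, so the weakest growth inhibitor here. Swapping methoxy for chloro gave an 11-fold lower number from compound 1 to compound 2 (1.05 log units; beyond the scatter), methoxy for dimethylamino gave an 8.0-fold higher number from compound 1 to compound 3 (0.91 log units; beyond the scatter), and chloro for dimethylamino gave a 91-fold higher number from compound 2 to compound 3 (1.96 log units; beyond the scatter).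

Compound 4 `CN(C)c1ccc(C2CC(c3ccccc3)=NN2C2=NC(=O)/C(=C3\C(=O)Nc4ccc(Cl)cc43)S2)cc1` keeps the dimethylamino of compound 3 and adds a second change: chloro in place of hydrogen on an aromatic carbon, on a six-membered carbon-only aromatic ring that is part of a fused two-ring system, meta to a fused ring and para to a fused ring. Among the measured compounds shown here, no measured step touches that ring, so the size of the effect is uncertain; the only hint is that chloro on the pendant ring helped, as seen from compound 1 to compound 2. A modest gain is therefore expected, a 2.9-fold lower number from compound 3 to compound 4 (0.47 log units; beyond the scatter), and compound 4 is estimated at 12000 nM, most likely between 3000 nM and 50000 nM.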

Compound 4, concentration for total growth inhibition: 410 nM
The estimate for compound 4 lay 29-fold (1.47 log units) above the measured number, outside the stated range (below it).
By their numbers in this assay, from the lowest: compounds 2 and 4 (each within the scatter of the next); then compound 1; then compound 3.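

Among the compounds shown here, this is the first change on the fused ring, and the position, on an aromatic carbon of the six-membered ring, meta to a fused ring and para to a fused ring, proves highly sensitive: chloro in place of hydrogen gives an 86-fold lower number from compound 3 to compound 4 (1.93 log units; beyond the scatter) in this assay. The pendant ring is therefore not the only place where one small change moves the number strongly, and a compound carrying dimethylamino need not stay at a high number. Nothing available explains why this single atom has so large an effect.

Going by these compounds, whether chloro at this position would have a similar effect alongside the methoxy of compound 1 or the pendant chloro of compound 2 remains open. Also open, on these data alone, is whether fluoro, methyl or a carboxylic acid there would match chloro.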